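Rat Liver Microsomal Stability: Dropping the Hydroxymethyl Group

This account rests on a few compounds, and the source may have more. Where it says the series, first, only, none or still open, it means among the compounds named here.

Measured compounds:
- compound 1, `Cc1cc(F)cnc1N1CCN(C(=O)CCCc2cccc3ncc(CO)cc23)[C@@H](C)C1`: 1%
- compound 2, `Cc1ccncc1N1CCN(C(=O)CCS(=O)(=O)c2cccc3ncsc23)CC1`: "not determined" (no result reported)

This account follows the change from compound 1 to compound 3, `Cc1cc(F)cnc1N1CCN(C(=O)CCCc2cccc3ncccc23)[C@@H](C)C1`. The data come from an ADME assay on microsomes from liver (Rattus norvegicus) for metabolic stability, read by LC-MS, with a stated time of 15 min, tested at 1 uM; a higher number here means that more of the compound is left, a lower number that less of the compound is left. In this assay, among the measured compounds shown here, compound 1 gives 1%, which places it at the low end of the read-out; it is in fact the only number reported, since compound 2 carries no result in this assay, so no step between measured compounds is available for comparison.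

The structural change is hydrogen in place of hydroxymethyl on an aromatic carbon: hydroxymethyl leaves and hydrogen enters on an aromatic carbon of the six-membered aromatic ring that contains one nitrogen, within the fused two-ring system, two atoms from the ring nitrogen.

For the measured compounds named here, with no measured step to lean on, the expected step from compound 1 to compound 3, a number 5 percentage points higher from compound 1 to compound 3 (within the scatter), is taken to be small and upward, most likely within or just beyond the usual scatter, because compound 1 already sits at 1% and the read-out can hardly fall further. Compound 3 is therefore estimated at 6%, with a range from 0% to 25%.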

Compound 3, percent of the compound remaining: 0.2%
Compound 3: middle estimate off by 5.8 percentage points, on the high side; the range from low to high includes it.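

Placing hydrogen in place of hydroxymethyl on an aromatic carbon gives, in this assay, a number 0.8 percentage points lower from compound 1 to compound 3 (within the scatter) and this is the first step that can be read at this position. The assay does not tell the two compounds apart: both stand at the low end of the read-out, so the hydroxymethyl group is not required for a reading there, and its loss does not lift the compound away from that end. No measurement that could explain this result accompanies it.

On these data alone, with both compounds so close to the bottom of the read-out, this one step says little about how the position would behave in a compound that keeps more of itself over the same time, and whether the same exchange would read alike in such a compound remains open. As far as these compounds go, it also remains open whether an amine, a carboxylic acid or a longer chain on this same aromatic carbon would give a reading that stands clear of the low end.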